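Side-chain variation on a shared core: permeability notes

This account rests on a few compounds, and the source may have more. Where it says the series, first, only, none or still open, it means among the compounds named here.

Three compounds on the shared core have been run in an ADME assay on MDCK-MDR1 cells (Canis lupus familiaris) for permeability, in the apical to basolateral direction, with a stated time of 180 min; on this read-out higher numbers stand for higher permeability and lower numbers for lower permeability. Compound 1 `CN(C)CCC(=O)Nc1ccc([C@H]2[C@@H](F)[C@@H](F)C[C@@H](F)[C@H]2F)cc1` gives 3.7 10^-6 cm/s in this assay. Compound 2 `NC(=O)CCNC(=O)c1ccc([C@H]2[C@@H](F)[C@@H](F)C[C@@H](F)[C@H]2F)cc1` gives 0.4 10^-6 cm/s, and compound 3 `O=C(c1ccc([C@H]2[C@@H](F)[C@@H](F)C[C@@H](F)[C@H]2F)cc1)N1CC(O)C1` gives 6.7 10^-6 cm/s. Compound 1 therefore stands second highest of the three numbers: the step of a 1.8-fold higher number from compound 1 to compound 3 (0.26 log units; within the scatter) is within the scatter, whereas a 9.3-fold lower number from compound 1 to compound 2 (0.97 log units; beyond the scatter) lies beyond it, as does a 17-fold higher number from compound 2 to compound 3 (1.22 log units; beyond the scatter).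

Compound 4 `CC(=O)N1CC(C(=O)Nc2ccc([C@H]3[C@@H](F)[C@@H](F)C[C@@H](F)[C@H]3F)cc2)C1` has not yet been measured. It differs from compound 1 in one place: 1-acetylazetidin-3-yl in place of 2-(dimethylamino)ethyl on a carbonyl carbon.

Both measured steps out of compound 1 bear on this, since each also exchanges the side chain attached through the amide. Their sizes span from a 9.3-fold lower number from compound 1 to compound 2 (0.97 log units; beyond the scatter) to a 1.8-fold higher number from compound 1 to compound 3 (0.26 log units; within the scatter), so the shared core tolerates this kind of exchange with outcomes from within the scatter to a modest drop. The entering 1-acetylazetidin-3-yl carries a four-membered ring, as does the group entering in compound 3, and no hydrogen-bond donor, unlike the group entering in compound 2. The expected step is therefore small to modest and more likely downward than upward, with a fair chance of falling within the scatter. Compound 4 is estimated at 2.5 10^-6 cm/s, with a range of 0.8 10^-6 cm/s to 8 10^-6 cm/s. This estimate corresponds to a 1.5-fold lower number from compound 1 to compound 4 (0.17 log units; within the scatter).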

Compound 4, apparent permeability: 0.6 10^-6 cm/s
Compound 4: middle estimate off by 4.2-fold (0.62 log units), on the high side, outside the stated range (below it).
By their numbers in this assay, from the lowest: compounds 2 and 4 (each within the scatter of the next); then compounds 1 and 3 (each within the scatter of the next).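

In this assay, the step at this carbonyl carbon, with the amide-type nitrogen left in place, is a 6.2-fold lower number from compound 1 to compound 4 (0.79 log units; beyond the scatter). The group carried on this carbon therefore matters even when the amide link stays unchanged, which the steps to compound 2 and compound 3 could not show, since each replaces the whole amide-linked side chain on an aromatic carbon. The leaving and entering groups match in their counts of hydrogen-bond donors and acceptors and in having no net charge, so these counts do not separate them, and nothing at hand explains the step.

The compounds shown leave open whether the lower number goes with the four-membered ring, with the acetyl group or with the loss of the dimethylamino group. Open-chain 2-acetamidoethyl, unacylated azetidin-3-yl and 1-methylazetidin-3-yl on the same carbonyl carbon would pull these features apart, and a longer chain such as 3-(dimethylamino)propyl would show how much change 2-(dimethylamino)ethyl itself tolerates.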